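Swapping trifluoromethyl for methoxy on a urea-linked phenyl ring

A few compounds are considered here, and "the series" means these few. Any claim that something is new, unique, unknown or untested is made for them only; others in the source may bear on it.

Three compounds share one core and differ only in the phenyl ring attached to the urea nitrogen. Compound 1 `Cc1cccc(NC(=O)Nc2nnc(Sc3ncnc4scc(-c5ccncc5)c34)s2)c1` carries a methyl on that ring and gives 5200 nM in a functional assay on PC-3 cells (Homo sapiens) for antiproliferative activity, read by MTT assay, with a stated time of 48 h; on this read-out lower numbers stand for stronger inhibition and higher numbers for weaker inhibition. Compound 2 `O=C(Nc1cccc(C(F)(F)F)c1)Nc1nnc(Sc2ncnc3scc(-c4ccncc4)c23)s1` carries a trifluoromethyl instead and gives 11500 nM, the highest number of the three, so compound 2 is the least potent of the set. Compound 3 `Cc1ccc(NC(=O)Nc2nnc(Sc3ncnc4scc(-c5ccncc5)c34)s2)cc1Cl`, with a 3-chloro-4-methylphenyl, gives 4700 nM.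

For the measured compounds named here, two measured steps bear on the trifluoromethyl position: a 2.2-fold higher number from compound 1 to compound 2 (0.34 log units; beyond the scatter) and a 2.4-fold lower number from compound 2 to compound 3 (0.39 log units; beyond the scatter). Both show that replacing the trifluoromethyl with another substituent lowers the number by a modest, though real, amount, while a 1.1-fold lower number from compound 1 to compound 3 (0.04 log units; within the scatter) shows little between the two alternatives.

Compound 4 `COc1cccc(NC(=O)Nc2nnc(Sc3ncnc4scc(-c5ccncc5)c34)s2)c1` is not yet measured. Relative to compound 2 the change is methoxy in place of trifluoromethyl on an aromatic carbon, on an aromatic carbon of a six-membered aromatic ring of carbon only, meta to a large group. Since every measured departure from trifluoromethyl gave a modest drop, a similar modest decrease is expected, as a 1.9-fold lower number from compound 2 to compound 4 (0.28 log units; within the scatter). Compound 4 is therefore estimated at 6000 nM, within a range from 2500 nM to 14000 nM.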

Compound 4, half-maximal inhibitory concentration: 6800 nM
Compound 4: the middle estimate sits 1.1-fold (0.05 log units) below what was measured, within the range that was stated.
By their numbers in this assay, from the lowest: compounds 3, 1, 4 and 2 (each within the scatter of the next, the first and the last beyond it).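

In this assay the step away from trifluoromethyl is a 1.7-fold lower number from compound 2 to compound 4 (0.23 log units; within the scatter) and so, unlike the two earlier steps away from that group, this exchange of trifluoromethyl for methoxy, which replaces four heavy atoms with two and adds one hydrogen-bond acceptor, gives no firm change in potency. The remaining comparisons, a 1.3-fold higher number from compound 1 to compound 4 (0.12 log units; within the scatter) and a 1.4-fold higher number from compound 3 to compound 4 (0.16 log units; within the scatter), are also inside the usual scatter, so the methoxy compound cannot be separated from either the methyl compound or the 3-chloro-4-methylphenyl compound. The trifluoromethyl compound therefore differs clearly from those two neighbours but not from the methoxy compound, and no supporting measurement explains this pattern.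

As far as these compounds go, it remains open whether an amine, a carboxylic acid or a longer chain in place of methoxy on this phenyl ring would move the number beyond the scatter. Also open, from the compounds shown here alone, is whether the exchange of trifluoromethyl for methoxy would read the same on a different core or in other cell lines.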